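This account rests on a few compounds, and the source may have more. Where it says the series, first, only, none or still open, it means among the compounds named here.

Compound 1 `Cc1ccncc1-c1ccc2[nH]c(=O)nc(-c3ccccc3)c2c1` carries a 4-methylpyridin-3-yl group on the shared core. In an ADME assay on THP-1 cells (Homo sapiens) for cytotoxicity, read by MTT assay, with a stated time of 72 h (a higher number here means that more compound is needed for the effect, a lower number that less compound is needed), compound 1 gives only a limit, > 50000 nM, and no number. Compound 2 `Cn1ccc(-c2cccc3[nH]c(=O)nc(-c4ccccc4)c23)n1` is the other member of the series with a reading in this assay. In this assay compound 2 also returns a limit, > 50000 nM. For the measured compounds named here, compound 1 therefore stands at the limit of the assay rather than at a measured number, and the same holds for the one further value shown: the limit of > 50000 nM in this assay, at which 2 of the 2 values shown sit. Going by the values given here, no step between two measured numbers exists in this assay, so no direction or size can be read from the pair.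

Compound 3 `O=c1nc(-c2ccccc2)c2cc(N3CCNCC3)ccc2[nH]1` has not yet been measured in this assay. It differs from compound 1 in one place: piperazin-1-yl in place of 4-methylpyridin-3-yl on an aromatic carbon. Among the compounds with values here, with both recorded values sitting at the limit and no measured step available, for compound 3 the expected step in this assay is a number no higher from compound 1 to compound 3 (the limit leaves the size open), none beyond the scatter, and a limit is again the likely report. For compound 3 the estimate in this assay is 50000 nM, with a range from 20000 nM to 150000 nM.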

Compound 3, half-maximal effective concentration: > 25000 nM
Compound 3 gave a limit, no number; the forecaster's own chance of this, stated with the estimate: 85%; the middle value is on the limit's open side.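

Compound 1 and compound 3 each give a limit and no number in this assay, so no step between them can be read: the limit of > 25000 nM in this assay, at which 1 of the 3 values shown sits.

The compounds shown leave open at what concentration, if any, cytotoxicity appears in this assay, and whether piperazin-1-yl in place of 4-methylpyridin-3-yl on an aromatic carbon shifts that concentration.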